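Removing the sugar from compound 2

The source may report more compounds than this note shows. Statements on the series, on what has been measured and on what is new or still open speak of the compounds shown alone.

Compound 1 `O=C(CCCc1cn(CCOCCOCCOc2cc(O)c(C(=O)CCc3ccc(O)cc3)c(O[C@@H]3O[C@H](CO)[C@@H](O)[C@H](O)[C@H]3O)c2)nn1)OCn1cc(F)c(=O)[nH]c1=O` in a functional assay on HT-29 cells (Homo sapiens) for cytotoxicity, read by sulforhodamine B assay, with a stated time of 48 h (on this read-out lower numbers stand for stronger inhibition and higher numbers for weaker inhibition), gives only a limit, > 100000 nM. Compound 2 `O=C(CCc1ccc(O)cc1)c1c(O)cc(OCCOCCOCCS)cc1O[C@@H]1O[C@H](CO)[C@@H](O)[C@H](O)[C@H]1O` in this assay likewise gives only a limit, > 100000 nM. Going by the values given here, both results sit at the limit of > 100000 nM in this assay, at which 2 of the 2 values shown sit, so compound 2 stands on no numerical scale here, and no measured step exists. Compound 3 `O=C(CCc1ccc(O)cc1)c1c(O)cc(OCCOCCOCCS)cc1O` differs from compound 2 by hydrogen in place of 3,4,5-trihydroxy-6-(hydroxymethyl)oxan-2-yl on an oxygen on an aromatic ring. With nothing measured to lean on, the step from compound 2 to compound 3 in this assay is expected to be an at least 1.2-fold lower number from compound 2 to compound 3 (0.09 log units; that floor lies within the scatter), toward stronger inhibition, though possibly not beyond the scatter. Compound 3 is estimated at 80000 nM, within 25000 nM to 300000 nM.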

Compound 3, half-maximal inhibitory concentration: 29100 nM
Compound 3: the middle estimate sits 2.7-fold (0.44 log units) above what was measured; the measured number falls inside the stated range.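

Replacing 3,4,5-trihydroxy-6-(hydroxymethyl)oxan-2-yl with hydrogen on this oxygen gives, in this assay, an at least 3.4-fold lower number from compound 2 to compound 3 (0.53 log units; beyond the scatter), so the position responds to this change and compound 3 is the only compound shown with a numerical value. The full size of the step cannot be read because compound 2 gives only a limit: the limit of > 100000 nM in this assay, at which 2 of the 3 values shown sit.

As far as these compounds go, whether a methyl group on this oxygen would behave like the hydrogen of compound 3 remains open. So does whether a carboxylic acid in place of the thiol at the chain end would keep the value of compound 3.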